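Exchanging nitro for chloro at the edge of a limit

A few compounds are considered here, and "the series" means these few. Any claim that something is new, unique, unknown or untested is made for them only; others in the source may bear on it.

compound 1 `C#CCN(c1nc(-c2cccc([N+](=O)[O-])c2)no1)C1CCCCC1` — in an ADME assay on HepG2 cells (Homo sapiens) for cytotoxicity, read by MTT assay, with a stated time of 48 h (a higher number here means that more compound is tolerated, a lower number that less compound is tolerated), compound 1 gives 45.5 ug/mL.
compound 2 `CC(=O)OC[C@H]1O[C@H](OC[C@@H](Cn2cc(CN(c3nc(-c4cccc([N+](=O)[O-])c4)no3)C3CCCCC3)nn2)OC(C)=O)C=C[C@@H]1OC(C)=O` — in this assay compound 2 gives > 200 ug/mL, a limit of the assay rather than a number.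
compound 3 `CC(=O)OC[C@H]1O[C@H](OC[C@@H](Cn2cc(CN(c3nc(-c4ccc([N+](=O)[O-])cc4)no3)C3CCCCC3)nn2)OC(C)=O)C=C[C@@H]1OC(C)=O` — in this assay compound 3 gives > 200 ug/mL, likewise a limit of the assay.

Compound 3 therefore stands at the upper edge of what this assay can report, and no number is known for it. The step that the two limits leave unreadable from compound 2 to compound 3 cannot be read; both of its ends are limits. Compound 4 `CC(=O)OC[C@H]1O[C@H](OC[C@@H](Cn2cc(CN(c3nc(-c4ccc(Cl)cc4)no3)C3CCCCC3)nn2)OC(C)=O)C=C[C@@H]1OC(C)=O` differs from compound 3 by chloro in place of nitro on an aromatic carbon. Among the compounds with values here, no measured step covers this exchange; the only guidance is the limit of > 200 ug/mL in this assay, at which 2 of the 3 values shown sit. The expected step is a number no higher from compound 3 to compound 4 (the limit leaves the size open), not readable beyond the scatter. Compound 4 is estimated at 200 ug/mL, ranging from 100 ug/mL to 400 ug/mL, most probably again reported as a limit.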

Compound 4, half-maximal cytotoxic concentration: 46.9 ug/mL
Compound 4: the middle estimate sits 4.3-fold (0.63 log units) above what was measured, and the stated range ends above it.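

The earlier step on this ring could not be read, and the value for compound 3 is only a limit. In this assay chloro in place of nitro on this aromatic carbon gives an at least 4.2-fold lower number from compound 3 to compound 4 (0.62 log units; beyond the scatter) and 4-chlorophenyl in place of 3-nitrophenyl gives an at least 4.2-fold lower number from compound 2 to compound 4 (0.62 log units; beyond the scatter) as well. The group on this ring can therefore change how much compound the cells tolerate, which the two nitro compounds alone could not show.

From the compounds shown here alone, whether the drop follows from gaining chloro or from losing nitro stays open, and an amine or a methyl group at this place would help separate the two. Going by these compounds, the actual numbers for compound 2 and compound 3 also remain unknown.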